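Fluoro for Methoxy on the Aryl Ring of Compound 1

The source may hold more compounds than are shown below. What is called first, only, known or untested is meant among the compounds shown, and "the series" means these compounds.

Compound 1, `COc1ccccc1-c1nc(Cc2c[nH]c3ccccc23)no1`: 16700 nM in a functional assay on cells (Splenocyte, Mus musculus, strain BALB/c) for inhibition, read by scintillation counting and thymidine incorporation, with stated times of 48 h and 8 h; a higher number here means a weaker inhibitor, a lower number a stronger inhibitor.
Compound 2, `COc1ccc(-c2nc(Cc3c[nH]c4ccccc34)no2)c(OC)c1`: 8600 nM.
Compound 3, `COc1ccc(OC)c(-c2nc(Cc3c[nH]c4ccccc34)no2)c1`: a limit only, > 50000 nM.

Compound 1 carries the highest of the two numbers given; compound 2 lies a 1.9-fold lower number from compound 1 to compound 2 (0.29 log units; within the scatter), within the scatter. Compound 3 sits at the limit of > 50000 nM in this assay, at which 1 of the 3 values shown sits, so the step is an at least 2.9-fold higher number from compound 1 to compound 3 (0.47 log units; beyond the scatter). Compound 4, `Fc1ccccc1-c1nc(Cc2c[nH]c3ccccc23)no1`, differs from compound 1 by fluoro in place of methoxy on an aromatic carbon. Neither measured step touches this change: both add a methoxy elsewhere on the ring, one within the scatter and one beyond it, and neither removes the methoxy that compound 4 loses. No step beyond the scatter is therefore expected in this assay. Compound 4 is estimated at 20000 nM, between 6000 nM and 50000 nM, an expected step of a 1.2-fold higher number from compound 1 to compound 4 (0.08 log units; within the scatter).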

Compound 4, half-maximal inhibitory concentration: > 50000 nM
Compound 4: a limit, no number; the forecaster's own chance of this, stated with the estimate: 20%; at least 2.5-fold (0.39 log units) between middle value and limit.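

In this assay, the only change shown at this place on the ring, fluoro in place of methoxy ortho to a large group, gives an at least 2.9-fold higher number from compound 1 to compound 4 (0.47 log units; beyond the scatter). Among these compounds, the earlier steps left this methoxy in place, so only this step shows that it cannot be exchanged for fluoro without a loss. The value for compound 4 is a limit, not a number: the limit of > 50000 nM in this assay, at which 2 of the 4 values shown sit.

The compounds shown leave open whether the loss comes from the methoxy leaving or the fluoro entering. They also leave open whether an ethoxy, a hydroxyl or an amine at this place would keep the level of compound 1.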